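The compounds below may be only part of what the source reports. "The series", "measured", "known", "first", "only" and "open" are said of these compounds alone.

Working notes on the series. Compound 1 `CC(C)OC(=O)N1CCC2(CC1)CC(CCCOc1ccc(S(C)(=O)=O)c(F)c1)C2` is the reference point. Among the measured compounds shown here, in a functional assay on cells for agonist activity at Glucose-dependent insulinotropic receptor (Homo sapiens), read by HTRF and cAMP accumulation, with a stated time of 30 min (on this read-out lower numbers stand for an effect already at smaller amounts and higher numbers for an effect only at larger amounts of compound), compound 1 gives 18 nM, the lowest of the two numbers measured so far. For the measured compounds named here, the only other measured member, compound 2 `CCc1cnc(N2CCC3(CC2)CC(CCCOc2ccc(S(C)(=O)=O)c(F)c2)C3)nc1`, gives 123 nM in this assay. Going by the values given here, the one measured step, a 6.8-fold higher number from compound 1 to compound 2 (0.83 log units; beyond the scatter), concerns the group on the ring amine nitrogen and leaves the aromatic end of the molecule untouched.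

Compound 3 `CC(C)OC(=O)N1CCC2(CC1)CC(CCCOc1ccc(C(=O)N3CC(O)C3)c(F)c1)C2` keeps the isopropoxycarbonyl of compound 1 and alters the aromatic end instead: (3-hydroxyazetidin-1-yl)carbonyl in place of methylsulfonyl on an aromatic carbon. Among the compounds with values here, no measured step touches this position, so the single step in hand gives no direct guidance on its size or direction. The expectation therefore rests on compound 1 alone, widened to allow for either outcome. For compound 3 the number in this assay is estimated at 35 nM, with a range of 7 nM to 180 nM. This estimate amounts to an expected step of a 1.9-fold higher number from compound 1 to compound 3 (0.29 log units; within the scatter), which is to say no change that can be asserted beyond the scatter.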

Compound 3, half-maximal effective concentration in the Glucose-dependent insulinotropic receptor assay: 40 nM
The estimate for compound 3 lay 1.1-fold (0.06 log units) below the measured number; the measured number falls inside the stated range.
By their numbers in the Glucose-dependent insulinotropic receptor assay, from the lowest: compound 1; then compound 3; then compound 2.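

The aromatic position accepts a much larger group than methylsulfonyl with only a modest shift: in the Glucose-dependent insulinotropic receptor assay, (3-hydroxyazetidin-1-yl)carbonyl in place of methylsulfonyl gives a 2.2-fold higher number from compound 1 to compound 3 (0.35 log units; beyond the scatter). In a physicochemical assay for solubility, read by HPLC, in phosphate buffer, with a stated time of 24 h, at pH 6.8 (a lower number here means a less soluble compound, a higher number a more soluble compound), the same change at this position raises solubility, a property that no earlier comparison addressed: the measured solubility of compound 1, < 0.16 ug/mL, and of compound 3, 1.89 ug/mL, an at least 11-fold higher number (1.07 log units; beyond the scatter) In the physicochemical assay compound 3 gives 1.89 ug/mL as a measured number. In the physicochemical assay compound 1 gives < 0.16 ug/mL as a limit of the assay and not a number, so the true size of this step stays unfixed: the limit of < 0.16 ug/mL in the physicochemical assay, at which 1 of the 2 values shown sits.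

The compounds shown do not separate the contributions of the carbonyl, the four-membered ring and its hydroxy group, so it remains open whether a dimethylaminocarbonyl group, a carboxylic acid or a 3-methoxyazetidin-1-ylcarbonyl group at this position would keep the number in the Glucose-dependent insulinotropic receptor assay and the gain in the physicochemical assay. From the compounds shown here alone, it also remains open whether the same exchange on compound 2, with its 5-ethylpyrimidin-2-yl group on the ring amine nitrogen, would give steps of similar size and direction.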